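Amide nitrogen substituent change on a shared core

The source may report more compounds than this note shows. Statements on the series, on what has been measured and on what is new or still open speak of the compounds shown alone.

Measured compounds:
Compound 1, `O=C(Nc1cccc(F)c1)c1cncc(N2CC3CC(C2)N3)c1`, gives 28 nM in an assay on cells for displacement of a labelled ligand from Neuronal acetylcholine receptor; alpha3/beta4 (Homo sapiens); on this read-out lower numbers stand for stronger inhibition and higher numbers for weaker inhibition.
Compound 2, `O=C(Nc1ccccc1F)c1cncc(N2CC3CC(C2)N3)c1`, gives 102 nM in this assay.
Compound 3, `CCc1cccc(NC(=O)c2cncc(N3CC4CC(C3)N4)c2)c1`, gives 306 nM in this assay.

Compound 3 stands at the highest number of the three. The step of an 11-fold higher number from compound 1 to compound 3 (1.04 log units; beyond the scatter) was large, and the step of a 3.0-fold higher number from compound 2 to compound 3 (0.48 log units; beyond the scatter) was modest; compound 1 to compound 2 showed a 3.6-fold higher number from compound 1 to compound 2 (0.56 log units; beyond the scatter). Compound 4, `O=C(NCc1ccccc1)c1cncc(N2CC3CC(C2)N3)c1`, carries benzyl in place of 3-ethylphenyl on an amide-type nitrogen. Going by the values given here, no measured step replaces an aryl group on this nitrogen with a benzyl group, so the three steps bear on it only by showing that changes at this nitrogen move the number by modest to large amounts. Compound 4 is therefore expected to remain near compound 3, with the step of a 1.1-fold higher number from compound 3 to compound 4 (0.06 log units; within the scatter), and its estimated value is 350 nM, within 100 nM to 1200 nM.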

Compound 4, inhibition constant: 1600 nM
Estimate against measurement, compound 4: 4.6-fold (0.66 log units) below; measured number outside the range, above it.
By their numbers in this assay, from the lowest: compound 1; then compound 2; then compound 3; then compound 4.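

In this assay, benzyl on the amide-type nitrogen gave the highest number of the four, above all three compounds with an aryl group there (a 5.2-fold higher number from compound 3 to compound 4 (0.72 log units; beyond the scatter); a 16-fold higher number from compound 2 to compound 4 (1.20 log units; beyond the scatter); a 57-fold higher number from compound 1 to compound 4 (1.76 log units; beyond the scatter)). The last of these steps is larger than any step among the aryl compounds, so in this set the change to benzyl moved the number further than swapping one aryl group for another. Nothing available here accounts for this. Left open is whether a fluorobenzyl group would bring the number back towards that of compound 1, and how a longer chain such as phenethyl would read.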